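Adding a Hydroxy Group to an Aromatic Side Chain

The source may report more compounds than this note shows. Statements on the series, on what has been measured and on what is new or still open speak of the compounds shown alone.

Three compounds share a common core: compound 1 `COC(=O)c1c(CCc2ccccc2)cc2c(c1O)CC(C(C)(C)O)O2`, compound 2 `COC(=O)c1c(CCc2ccccc2)cc2c(c1O)CC(O)C(C)(C)O2` and compound 3 `CC1=CCc2c(O)cc(CCc3ccccc3)cc2OC1`. Each was tested in a functional assay on HepG2 cells (Homo sapiens) for cytotoxicity, read by MTT assay, with a stated time of 48 h; a higher number here means a weaker inhibitor, a lower number a stronger inhibitor. Compound 1 reaches only a limit of the assay, > 40000 nM. Compound 2 likewise gives only a limit, > 40000 nM. Compound 3 also stops at a limit, > 40000 nM, so no number is known for it. Together these three results amount to the limit of > 40000 nM in this assay, at which 3 of the 3 values shown sit. Compound 4 `CC1=CCc2c(O)cc(CCc3ccccc3O)cc2OC1` differs from compound 3 by hydroxy in place of hydrogen on an aromatic carbon. Within the data shown here, with no measured step between compounds to go by, the expected step that the limit leaves unreadable from compound 3 to compound 4 is none beyond the scatter. Compound 4 is therefore expected to give about 50000 nM in this assay, within a range from 20000 nM to 150000 nM, and most likely to be reported again only as a limit.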

Compound 4, half-maximal inhibitory concentration: 28200 nM
Beside the measured number, compound 4's estimate is 1.8-fold (0.25 log units) above it; measured number inside the range.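

Phenyl to 2-hydroxyphenyl is the one change here that yields a number rather than a limit, while the other compounds stay at that limit: the limit of > 40000 nM in this assay, at which 3 of the 4 values shown sit.

The change can be sized only as an at least 1.4-fold lower number from compound 3 to compound 4 (0.15 log units; that floor lies within the scatter), so it need not be a real gain in potency.

As far as these compounds go, it remains open whether a methoxy group, an amine or a carboxylic acid at this position would give a clearer step. From the compounds shown here alone, it also remains open whether the same hydroxy would give a readable number on the core of compound 1.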